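The source may report more compounds than this note shows. Statements on the series, on what has been measured and on what is new or still open speak of the compounds shown alone.

Working notes on the series. Compound 1 `O=COC1(C(=O)Nc2ccc([N+](=O)[O-])cc2)CCCCC1` and compound 2 `CC(=O)OC1(C(=O)Nc2ccc([N+](=O)[O-])cc2)CCCCC1` share a core and differ only at the carbonyl carbon of the ester. In a functional assay on HepG2 cells (Homo sapiens) for inhibition, read by MTT assay, with a stated time of 72 h (on this read-out lower numbers stand for stronger inhibition and higher numbers for weaker inhibition), compound 1 gives 34.1 nM, while compound 2 gives 519 nM; the step of a 15-fold higher number from compound 1 to compound 2 (1.18 log units; beyond the scatter) is the only measured one. Compound 2 therefore stands with the higher of the two numbers, compound 1 being the nearest point of comparison.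

Compound 3 `CC(=O)Oc1ccccc1C(=O)OC1(C(=O)Nc2ccc([N+](=O)[O-])cc2)CCCCC1` takes the same position further: 2-acetoxyphenyl in place of methyl on a carbonyl carbon. Within the data shown here, the one step that bears on this change, a 15-fold higher number from compound 1 to compound 2 (1.18 log units; beyond the scatter), shows that enlarging the group on that carbonyl carbon raised the number markedly. Among the measured compounds shown here, no measured pair tells how a far larger replacement behaves here, so the direction is uncertain; a further rise is the more likely outcome, and the step of a 1.7-fold higher number from compound 2 to compound 3 (0.24 log units; within the scatter) is the expected size. Compound 3 is estimated at 900 nM, with a range from 200 nM to 4000 nM.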

Compound 3, half-maximal inhibitory concentration: 17.7 nM
Estimate against measurement, compound 3: 51-fold (1.71 log units) above, and the stated range ends above it.
By their numbers in this assay, from the lowest: compounds 3 and 1 (each within the scatter of the next); then compound 2.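

The number at this carbonyl carbon does not follow the size of the group: in this assay 2-acetoxyphenyl in place of methyl gives a 29-fold lower number from compound 2 to compound 3 (1.47 log units; beyond the scatter) and so reverses the direction of a 15-fold higher number from compound 1 to compound 2 (1.18 log units; beyond the scatter) on this series. Against the hydrogen of compound 1, the same group gives a 1.9-fold lower number from compound 1 to compound 3 (0.28 log units; within the scatter) and stays within the scatter, so compound 1 and compound 3 stand level and compound 2 alone stands apart among the three. No measurement at hand bears on the reason for this turn.

Whether the acetoxy group or the aromatic ring accounts for the step from methyl remains open. A plain phenyl, a hydroxyphenyl or an ethyl group at this carbonyl carbon would bear on that question.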